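Metabolic stability across a small amide series

The source may hold more compounds than are shown below. What is called first, only, known or untested is meant among the compounds shown, and "the series" means these compounds.

Measured so far:
- compound 1, `C[C@@]1(c2cc(NC(=O)c3cnc(OCF)cn3)ccc2F)C=C(CF)OC(N)=N1`: 52%
- compound 2, `C[C@@]1(c2cc(NC(=O)c3ncc(OCF)nc3N)ccc2F)C=C(CF)OC(N)=N1`: 35%
- compound 3, `COc1cnc(C(=O)Nc2ccc(F)c([C@]3(C)C=C(CF)OC(N)=N3)c2)cn1`: 13%

In an ADME assay on microsomes from liver (Rattus norvegicus, strain Crj;CD(SD)) for metabolic stability, read by LC-MS, using NADPH, with a stated time of 30 min, tested at 0.1 uM (a higher number here means that more of the compound is left, a lower number that less of the compound is left), compound 1 stands highest of the three numbers. The nearest is compound 2, a step of a number 17 percentage points lower from compound 1 to compound 2 (beyond the scatter); the furthest is compound 3, a step of a number 39 percentage points lower from compound 1 to compound 3 (beyond the scatter). Between them lies a number 22 percentage points lower from compound 2 to compound 3 (beyond the scatter).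

Compound 4, `COc1cc(C#N)cnc1C(=O)Nc1ccc(F)c([C@]2(C)C=C(CF)OC(N)=N2)c1`, has not yet been measured. It differs from compound 1 in this way: 5-cyano-3-methoxypyridin-2-yl in place of 5-(fluoromethoxy)pyrazin-2-yl on a carbonyl carbon. Among the compounds with values here, of the measured steps, the one from compound 1 to compound 3, where a hydrogen replaced the fluoro on the saturated chain carbon bound to an oxygen on the aromatic ring, bears most on it, since compound 4 also carries a methoxy rather than a fluoromethoxy; that step was large, a number 39 percentage points lower from compound 1 to compound 3 (beyond the scatter). The step from compound 1 to compound 2, a number 17 percentage points lower from compound 1 to compound 2 (beyond the scatter), shows that even a small addition on the aromatic ring moved the number beyond the scatter. Within the data shown here, no measured step covers the cyano group or the change from a ring with two heteroatoms to one with one, so that part remains open.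

Taken together, a downward step is expected for compound 4, estimated at a number 27 percentage points lower from compound 1 to compound 4 (beyond the scatter), though smaller than the step to compound 3 given the uncertain contribution of the cyano group. The expected value for compound 4 is 25%, with a range from 8% to 45%.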

Compound 4, percent of the compound remaining: 60%
Estimate against measurement, compound 4: 35 percentage points below; measured number outside the range, above it.
By their numbers in this assay, from the lowest: compound 3; then compound 2; then compounds 1 and 4 (each within the scatter of the next).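

In this assay a methoxy group on the aromatic ring at this carbonyl carbon does not by itself go with a low number: 5-cyano-3-methoxypyridin-2-yl in place of 5-methoxypyrazin-2-yl gives a number 47 percentage points higher from compound 3 to compound 4 (beyond the scatter) in this series, something compound 3 alone could not show. A fluoromethoxy group is also not required for a number on the level of compound 1, as the exchange of 5-(fluoromethoxy)pyrazin-2-yl for 5-cyano-3-methoxypyridin-2-yl amounts to a number 8 percentage points higher from compound 1 to compound 4 (within the scatter) and so leaves the two compounds within the usual scatter. Set against 3-amino-5-(fluoromethoxy)pyrazin-2-yl, the same group gives a number 25 percentage points higher from compound 2 to compound 4 (beyond the scatter) here, so in these compounds the result follows the whole group on the carbonyl carbon and not the ether alone.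

On these data alone, compound 4 differs from compound 3 in the nitrile, in the ring hetero atoms and in where the methoxy group sits, so the share of each remains open, as does whether a chloro group or a primary carboxamide in place of the nitrile would give a similar number. Nothing measured here accounts for the result, and its cause therefore stays unassigned.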